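From Cyclohexyl Amide to Methyl Ester: an Uncertain Step

The source may hold more compounds than are shown below. What is called first, only, known or untested is meant among the compounds shown, and "the series" means these compounds.

Compound 1 `COc1cccc(OC)c1C(=O)Nc1c[nH]nc1C(=O)N[C@H]1CC[C@H](OC)CC1` gives 31000 nM in an ADME assay on MRC5 cells (Homo sapiens) for inhibition, with a stated time of 72 h (a lower number here means that less compound is needed, a higher number that more compound is needed for the effect), the only number shown. Compound 2 `COc1cc(OC)c(C(=O)Nc2c[nH]nc2C(=O)N[C@H]2CC[C@H](OC)CC2)c(OC)c1` shows only a limit, > 50000 nM, in this assay; that is the limit of > 50000 nM in this assay, at which 1 of the 2 values shown sits. For the measured compounds named here, the one measured step, an at least 1.6-fold higher number from compound 1 to compound 2 (0.20 log units; that floor lies within the scatter), concerns an aromatic carbon and does not touch the carbonyl carbon changed here. Compound 3 `COC(=O)c1n[nH]cc1NC(=O)c1c(OC)cccc1OC` differs from compound 1 by methoxy in place of (4-methoxycyclohexyl)amino on a carbonyl carbon. Going by the values given here, no measured step bears on this change, so the direction is open; compound 3 is expected to give a somewhat higher number, a 1.5-fold higher number from compound 1 to compound 3 (0.16 log units; within the scatter). Compound 3 is estimated at 45000 nM, between 15000 nM and 150000 nM.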

Compound 3, half-maximal effective concentration: > 50000 nM
Compound 3: only a limit was reported; the forecaster's own chance of this, stated with the estimate: 45%; middle value at least 1.1-fold (0.04 log units) away from the limit.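

At this carbonyl carbon, methoxy in place of (4-methoxycyclohexyl)amino gives an at least 1.6-fold higher number from compound 1 to compound 3 (0.20 log units; that floor lies within the scatter). The value of compound 3 is a limit and not a number, so this step fixes only a floor, and the change shows no lower number on losing the six-membered ring. Compound 3 thus joins the compounds that give only a limit: the limit of > 50000 nM in this assay, at which 2 of the 3 values shown sit.

From the compounds shown here alone, how far compound 3 really lies from compound 1 stays open. So does what a carboxylic acid or a methylamino group on this carbonyl carbon would give.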